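The source may report more compounds than this note shows. Statements on the series, on what has been measured and on what is new or still open speak of the compounds shown alone.

Compound 1 `O=c1ccoc2cc(OCc3cn(Cc4ccccc4)nn3)ccc12` in a functional assay on QGY7701 cells (Homo sapiens) for cytotoxicity, read by MTT assay, with a stated time of 48 h (a lower number here means a stronger inhibitor, a higher number a weaker inhibitor), gives only a limit, > 100000 nM. Compound 2 `O=c1ccoc2cc(OCc3cn(Cc4cccc(Br)c4)nn3)ccc12` gives 17600 nM in this assay. Going by the values given here, in this set compound 2 holds the only number; the limit of > 100000 nM in this assay, at which 1 of the 2 values shown sits, is the other entry. Among the compounds with values here, the single measured step, an at least 5.6-fold lower number from compound 1 to compound 2 (0.75 log units; beyond the scatter), attends the arrival of bromo. Compound 3 `Cc1ccccc1Cn1cc(COc2ccc3c(=O)ccoc3c2)nn1` carries 2-methylphenyl in place of 3-bromophenyl on a saturated chain carbon bound to an aromatic nitrogen. Within the data shown here, no measured step covers methyl or this place on the ring, and the bromo step runs the other way, so a move back toward the limit is expected: a 2.6-fold higher number from compound 2 to compound 3 (0.41 log units; beyond the scatter). Compound 3 is expected to give 45000 nM, within 15000 nM to 130000 nM.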

Compound 3, half-maximal inhibitory concentration: > 100000 nM
Compound 3: a limit, no number (the forecaster's own chance of this, stated with the estimate: 35%); middle value at least 2.2-fold (0.34 log units) away from the limit.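

With 2-methylphenyl in place of 3-bromophenyl, an at least 5.6-fold higher number from compound 2 to compound 3 (0.75 log units; beyond the scatter) shows that a ring substituent alone does not secure a measurable value in this assay. Going by these compounds alone, compound 2 remains the only compound giving a number, while compound 3 gives only a limit. The step from compound 1 to compound 3 cannot be read, because both compounds sit at a limit: the limit of > 100000 nM in this assay, at which 2 of the 3 values shown sit.

The step from 3-bromophenyl to 2-methylphenyl changes both the group and its ring position, leaving their contributions unseparated. Going by these compounds, whether a chloro or methoxy group on the phenyl ring would give a number also remains open.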